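Swapping Bromine for Fluorine on a Pyridine Ring

The source may report more compounds than this note shows. Statements on the series, on what has been measured and on what is new or still open speak of the compounds shown alone.

In a functional assay on HOS-TE85 cells (Homo sapiens) for inhibition, read by CCK-8 assay, with a stated time of 72 h (on this read-out lower numbers stand for stronger inhibition and higher numbers for weaker inhibition), compound 3 `O=C(NCCCCn1cccn1)c1cccc(C2SCC(=O)N2c2cc(Br)ccn2)c1` gives 105 nM, the lowest of the two numbers shown. Its nearest neighbour, compound 1 `COc1ccc(C)cc1N1C(=O)CSC1c1cccc(C(=O)NCCCCc2ccccc2)c1`, gives 300 nM. Compound 2 `O=C(NCCCCc1ccccc1)c1cccc(C2SCC(=O)N2c2cnccn2)c1` gives > 1000 nM, which is a limit of the assay rather than a number (the limit of > 1000 nM in this assay, at which 1 of the 3 values shown sits). Within the data shown here, the only measured step, an at least 3.3-fold higher number from compound 1 to compound 2 (0.52 log units; beyond the scatter), concerns a different part of the molecule, so no measured step speaks directly to the change studied here. Compound 4 `O=C(NCCCCn1cccn1)c1cccc(C2SCC(=O)N2c2cc(F)ccn2)c1` differs from compound 3 by fluoro in place of bromo on an aromatic carbon. With nothing measured at this position, compound 4 is expected to stay within the usual scatter of compound 3, and its estimate is 160 nM, in a range from 60 nM to 450 nM. The expected step of a 1.5-fold higher number from compound 3 to compound 4 (0.18 log units; within the scatter) is accordingly small.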

Compound 4, half-maximal inhibitory concentration: 33.2 nM
Compound 4: middle estimate off by 4.8-fold (0.68 log units), on the high side, and the stated range ends above it.
By their numbers in this assay, from the lowest: compound 4; then compound 3; then compound 1. At a limit, above all of these: compound 2.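

In this assay, among these compounds, the halogen opposite the ring nitrogen matters: 4-fluoropyridin-2-yl in place of 4-bromopyridin-2-yl gives a 3.2-fold lower number from compound 3 to compound 4 (0.50 log units; beyond the scatter) and so shows that exchanging this single atom moves the read-out beyond the usual scatter, which no earlier step could show. Nothing shown here explains why fluoro gives the lower number. Going by these compounds, what chlorine, a methoxy group or an amine would give at this same place stays open, and so does whether the same exchange would have a similar effect with a different chain on the amide.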